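The source may report more compounds than this note shows. Statements on the series, on what has been measured and on what is new or still open speak of the compounds shown alone.

Working notes on the series.

The common core carries a piperazine on a pyrazole that bears an aryl ring; compound 1 `COc1ccccc1-c1n[nH]cc1N1CCNCC1` and compound 2 `COc1ccc(-c2n[nH]cc2N2CCNCC2)cc1` differ in the methoxy on that aryl ring. In an assay on isolated protein for binding affinity to 5-hydroxytryptamine receptor 6 (Homo sapiens) (on this read-out higher numbers stand for weaker inhibition and lower numbers for stronger inhibition), compound 1 gives > 10000 nM, which is a limit of the assay rather than a number (the limit of > 10000 nM in this assay, at which 1 of the 2 values shown sits). In this assay, going by the values given here, compound 2 gives 279 nM, the only measured number in the set. Compound 3 `c1ccc(-c2n[nH]cc2N2CCNCC2)cc1` has not yet been measured and differs from compound 2 by hydrogen in place of methoxy on an aromatic carbon, para to a large group. Among the compounds with values here, no measured pair shows this change. For compound 3 the expected step in this assay is a 2.0-fold higher number from compound 2 to compound 3 (0.29 log units; within the scatter), a modest loss of affinity. For compound 3 the estimate in this assay is 550 nM, expected between 150 nM and 2000 nM.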

Compound 3, inhibition constant: 185 nM
Compound 3: the middle estimate sits 3.0-fold (0.47 log units) above what was measured; the measured number falls inside the stated range.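

In this assay, replacing methoxy with hydrogen on the aromatic carbon para to a large group gives a 1.5-fold lower number from compound 2 to compound 3 (0.18 log units; within the scatter), so at this place methoxy is tolerated but is not needed for affinity. The same replacement starting from compound 1 gives an at least 54-fold lower number from compound 1 to compound 3 (1.73 log units; beyond the scatter), so the loss of affinity goes with the methoxy of compound 1 and not with the aryl ring itself. Compound 1 stands at a limit of the assay, not at a number: the limit of > 10000 nM in this assay, at which 1 of the 3 values shown sits.

As far as these compounds go, it remains open whether another group at the para carbon, such as an amine, a carboxylic acid or a longer alkoxy chain, would move the value beyond the scatter. Also open, from the compounds shown here alone, is whether a smaller group, such as fluorine, would be accepted where compound 1 carries its methoxy.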